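The source may hold more compounds than are shown below. What is called first, only, known or untested is meant among the compounds shown, and "the series" means these compounds.

Of the compounds shown here, three that share one core have been tested in a functional assay, read by spectrophotometry, with a stated time of 1 h; on this read-out higher numbers stand for weaker inhibition and lower numbers for stronger inhibition. Compound 1 `O=c1[nH]c2ccccc2cc1/C=N/O` gives 2010000 nM, and compound 2 `Cc1ccc2[nH]c(=O)c(/C=N/O)cc2c1` gives 1980000 nM; the step of a 1.0-fold lower number from compound 1 to compound 2 (0.01 log units; within the scatter) lies within the scatter. Compound 3 `NS(=O)(=O)CC(=O)N/N=C/c1cc2ccccc2[nH]c1=O` gives 8730000 nM, the highest of the three numbers, and its distance to compound 1 and to compound 2 is beyond the scatter in both cases. The unmeasured compound 4 `O=c1[nH]c2ccccc2cc1/C=N/Nc1ccccc1` differs from compound 3 by phenyl in place of (sulfamoylmethyl)carbonyl on an amine nitrogen. Among the measured compounds shown here, no measured step covers this kind of change: the only measured step, from compound 1 to compound 2, concerns a methyl on an aromatic carbon, and it stayed within the scatter. Compound 1 and compound 3 are not a pair that differs in one place, but their two values show that this part of the molecule can move this assay beyond the scatter. Compound 4 is therefore expected to show a step of a 2.9-fold lower number from compound 3 to compound 4 (0.46 log units; beyond the scatter). The expected value for compound 4 is 3000000 nM, within a range from 1000000 nM to 9000000 nM.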

Compound 4, half-maximal inhibitory concentration: 1000000 nM
Estimate against measurement, compound 4: 3.0-fold (0.48 log units) above, within the range that was stated.
By their numbers in this assay, from the lowest: compounds 4, 2 and 1 (each within the scatter of the next); then compound 3.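

In this assay, putting phenyl in place of (sulfamoylmethyl)carbonyl on the amine nitrogen gives an 8.7-fold lower number from compound 3 to compound 4 (0.94 log units; beyond the scatter) and so points to stronger inhibition; the only earlier step, a methyl on an aromatic carbon, stayed within the scatter, so this is the first single change shown to move the number beyond it. The change removes a chain with no ring, one hydrogen-bond donor and three hydrogen-bond acceptors, and brings in a six-membered aromatic ring of carbon only, with neither donors nor acceptors. No measurement at hand explains the step, so which of these differences matters remains unknown.

An acetyl group on this nitrogen would help show whether losing the sulfamoyl part is enough, while a cyclohexyl ring would test whether the ring must be aromatic. On these data alone, whether the step would hold on the methyl-bearing core of compound 2 also remains open.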